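This account rests on a few compounds, and the source may have more. Where it says the series, first, only, none or still open, it means among the compounds named here.

Of the compounds shown here, two that share one core have so far been tested in a functional assay on HepG2 cells (Homo sapiens) for cytotoxicity, read by MTT assay, with a stated time of 72 h; a lower number here means a stronger inhibitor, a higher number a weaker inhibitor. Compound 1, `CNC(=O)c1cc(Oc2ccc(C(=O)/C=C/c3cc(OC)c(OC)c(OC)c3)cc2)ccn1`, gives 560 nM in this assay. Compound 2, `CNC(=O)c1cc(Oc2ccc(C(=O)/C=C/c3ccc(C#N)cc3)cc2)ccn1`, carries a 4-cyanophenyl end instead and gives 5430 nM, the higher of the two numbers; its gap to compound 1 lies beyond the scatter, so compound 2 is the weaker inhibitor of the pair. For the measured compounds named here, no step between measured compounds that differ in a single place is available. Compound 3, `CNC(=O)c1cc(Oc2ccc(C(=O)/C=C/c3ccccc3)cc2)ccn1`, is not yet measured and differs from compound 2 as follows: hydrogen in place of cyano on an aromatic carbon. Nothing measured shows what taking the cyano away from this end does here, so the expectation rests on the two numbers above. The cyano compound stands well below the trimethoxy one, and a plain phenyl is expected to stay in that weaker region rather than recover the number of compound 1. The step of a 1.4-fold lower number from compound 2 to compound 3 (0.13 log units; within the scatter) is expected to be small, within the scatter or at most a modest move toward a lower number. Compound 3 is therefore estimated at 4000 nM, with a range from 1500 nM to 12000 nM.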

Compound 3, half-maximal inhibitory concentration: 6640 nM
Estimate against measurement, compound 3: 1.7-fold (0.22 log units) below; the range from low to high includes it.
By their numbers in this assay, from the lowest: compound 1; then compounds 2 and 3 (each within the scatter of the next).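

In this assay, for the compounds shown here, putting hydrogen in place of cyano on an aromatic carbon, para to a large group, is the first change in a single place that can be read, and it gives a 1.2-fold higher number from compound 2 to compound 3 (0.09 log units; within the scatter) within the shared core. At this position, the cyano group, with its triple bond, can therefore be exchanged for hydrogen without the number moving beyond the scatter, so the 4-cyanophenyl and phenyl ends cannot be told apart in this assay. No independent data are available to explain this result.

On these data alone, only cyano and hydrogen can be compared directly at this position, so it remains open whether an amine, a carboxylic acid or a longer chain placed there would leave the number unchanged or move it. Also open, as far as these compounds go, is how much each of the three methoxy groups contributes on the end of compound 1, which gives 560 nM, a question that a phenyl end carrying a single methoxy group could begin to answer.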